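The source may hold more compounds than are shown below. What is called first, only, known or untested is meant among the compounds shown, and "the series" means these compounds.

Measured so far:
- compound 1, `CC[C@H](C)[C@H](NC(=O)CN(c1nc(Cl)nc2[nH]cnc12)C1CC1)C(=O)O` — in a functional assay on the whole organism (Tail, strain ICR) with Mus musculus as the target, in the tail flick test, with a stated time of 60 min, at a dose of 25 umol/kg by the oral route (on this read-out higher numbers stand for a stronger effect at the one dose given and lower numbers for a weaker effect), compound 1 gives 36%
- compound 2, `O=C(O)CC[C@H](NC(=O)CN(c1nc(Cl)nc2[nH]cnc12)C1CC1)C(=O)O` — in this assay compound 2 gives 33.3%
- compound 3, `C[C@@H](O)[C@H](NC(=O)CN(c1nc(Cl)nc2[nH]cnc12)C1CC1)C(=O)O` — in this assay compound 3 gives 30.1%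

All three share the same core and differ only in the side chain on the saturated chain carbon bound to an amide-type nitrogen and a carbonyl carbon. Of the three numbers, that of compound 3 is the lowest, yet a number 3.2 percentage points lower from compound 2 to compound 3 (within the scatter) and a number 5.9 percentage points lower from compound 1 to compound 3 (within the scatter) both lie within the scatter, as does a number 2.7 percentage points lower from compound 1 to compound 2 (within the scatter), so the three compounds cannot be told apart on these data.

Compound 4, `O=C(O)C[C@H](NC(=O)CN(c1nc(Cl)nc2[nH]cnc12)C1CC1)C(=O)O`, is the next compound in this series. Its change from compound 3 is carboxymethyl in place of 1-hydroxyethyl on a saturated chain carbon bound to an amide-type nitrogen and a carbonyl carbon. The step that bears most on it is the one where a chain carrying a carboxylic acid was already tried, a number 3.2 percentage points lower from compound 2 to compound 3 (within the scatter), and that step stayed within the scatter. On that basis no step beyond the scatter is expected, and the estimated step is a number 2.9 percentage points higher from compound 3 to compound 4 (within the scatter). Compound 4 is therefore expected to give about 33% in this assay, with a range from 22% to 44%.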

Compound 4, a percentage reported as activity, at one dose (the size of the read-out at that dose, not a potency): 38.9%
Beside the measured number, compound 4's estimate is 5.9 percentage points below it; low and high end bracket the measured number.
By their numbers in this assay, from the lowest: compounds 3, 2, 1 and 4 (each within the scatter of the next).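

In this assay carboxymethyl at this position, on a saturated chain carbon bound to an amide-type nitrogen and a carbonyl carbon, cannot be told apart from 1-hydroxyethyl (a number 8.8 percentage points higher from compound 3 to compound 4 (within the scatter)), from the longer 2-carboxyethyl chain (a number 5.6 percentage points higher from compound 2 to compound 4 (within the scatter)) or from sec-butyl (a number 2.9 percentage points higher from compound 1 to compound 4 (within the scatter)). The position has thus now taken four different side chains, and every step among them stays within the scatter, so compound 4 cannot be ranked above the others, and changing the length of the chain carrying the carboxylic acid has shown no readable effect. Nothing given here offers an explanation for these results.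

Still open, on these data alone, is whether a side chain ending in an amine, or a benzyl group, would move the number beyond the scatter. With only one dose, any difference in potency among these compounds also remains unknown.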